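Swapping the Sulfonyl Aromatic Ring in a Sulfonamide Pair

The source may report more compounds than this note shows. Statements on the series, on what has been measured and on what is new or still open speak of the compounds shown alone.

Of the compounds shown here, two built on the same core have been measured so far. Compound 1 `O=c1c2[nH]c(Cc3ccc(NS(=O)(=O)c4cccnc4)cc3)nc2n(CC2CC2)c(=O)n1Cc1ccccc1F` and compound 2 `CCCCn1c(=O)n(Cc2ccccc2F)c(=O)c2[nH]c(Cc3ccc(NC(C)=O)cc3)nc21` were both tested in an assay on isolated protein for inhibition of phosphoenolpyruvate carboxykinase, cytosolic [GTP] (Homo sapiens); a higher number here means a weaker inhibitor, a lower number a stronger inhibitor. In this assay compound 1 gives 1950 nM, and compound 2 gives 2110 nM. Compound 1 has the lower of these two numbers, but compound 2 sits within the usual scatter of it, so the two cannot be told apart on this evidence.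

Compound 3 `Cc1noc(C)c1S(=O)(=O)Nc1ccc(Cc2nc3c([nH]2)c(=O)n(Cc2ccccc2F)c(=O)n3CC2CC2)cc1` has not yet been measured. It differs from compound 1 in one place: 3,5-dimethyl-1,2-oxazol-4-yl in place of pyridin-3-yl on a sulfonyl sulfur. Within the data shown here, no pair of measured compounds shows what this kind of exchange does in this assay, so there is no measured step to lean on, and the expectation rests on the value of compound 1 together with the small size of the change.

Compound 3 is expected to give about 2000 nM in this assay, with a likely range from 700 nM to 6000 nM. The step from compound 1 to compound 3 is estimated as a 1.0-fold higher number from compound 1 to compound 3 (0.01 log units; within the scatter), which is not expected to reach beyond the scatter in either direction.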

Compound 3, half-maximal inhibitory concentration: 790 nM
Compound 3: the middle estimate sits 2.5-fold (0.40 log units) above what was measured; the range from low to high includes it.
By their numbers in this assay, from the lowest: compound 3; then compounds 1 and 2 (each within the scatter of the next).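

In this assay, the aromatic ring on the sulfonyl sulfur proves to be a place where a change can register: putting 3,5-dimethyl-1,2-oxazol-4-yl in place of pyridin-3-yl gives a 2.5-fold lower number from compound 1 to compound 3 (0.39 log units; beyond the scatter) and so moves the number beyond the usual scatter. Among these compounds, this is the first measured step, and it shows that the pyridin-3-yl ring is not needed to keep this level of inhibition, since a five-membered aromatic ring with two hetero atoms serves at least as well as the six-membered ring with one. Several things change together in this single exchange, including the ring size, the hetero atoms and the two methyl groups, and no measurement here gives a reason for the lower number or separates their shares.

The compounds shown leave open whether the two methyl groups matter, which an unsubstituted 1,2-oxazol-4-yl would test, and whether a plain phenyl ring or a simple methyl on the sulfonyl sulfur would hold the lower number. Among the compounds shown here, with only one pair to read, it also remains open whether the same exchange would give a similar step on a different version of the shared core.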